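The compounds below may be only part of what the source reports. "The series", "measured", "known", "first", "only" and "open" are said of these compounds alone.

Working notes on the series, measured in a functional assay on VCaP cells (Homo sapiens) for antiproliferative activity, read by propidium iodide staining, with a stated time of 96 h (on this read-out higher numbers stand for weaker inhibition and lower numbers for stronger inhibition), so far:

- compound 1 `CC(O)(CSc1cccc(OC(F)(F)F)c1)C(=O)Nc1cccc(S(F)(F)(F)(F)F)c1` gives 17500 nM
- compound 2 `CC(O)(COc1cc(C(F)(F)F)cc(C(F)(F)F)c1)C(=O)Nc1ccc(S(F)(F)(F)(F)F)cc1` gives 2600 nM
- compound 3 `CC(O)(CS(=O)(=O)c1ccc(F)cc1)C(=O)Nc1ccc(S(F)(F)(F)(F)F)cc1` gives 34200 nM

Compound 3 carries the highest of the three numbers, but its place at the top is not secure. Its value of 34200 nM lies within the usual scatter of compound 1 at 17500 nM and so cannot be separated from it. Only the gap to compound 2 at 2600 nM lies beyond the scatter, with compound 3 the weaker of that pair.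

The next compound to be tested is compound 4 `CC(O)(CS(=O)(=O)c1ccccc1C(F)(F)F)C(=O)Nc1ccc(S(F)(F)(F)(F)F)cc1`, which has 2-(trifluoromethyl)phenyl in place of 4-fluorophenyl on a sulfonyl sulfur. Among the measured compounds shown here, no two measured compounds differ in one place, so the data give no direct guide to the size of this step. For the measured compounds named here, the expectation rests on compound 3 at 34200 nM as the only measured compound with a sulfonyl sulfur. No step beyond the scatter is expected in this assay at this stage, with a slight lean towards a lower number. The estimated change (a 1.7-fold lower number from compound 3 to compound 4 (0.23 log units; within the scatter)) is therefore small. For compound 4 the estimate is 20000 nM with an expected range from 7000 nM to 50000 nM at this stage.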

Compound 4, half-maximal inhibitory concentration: 23800 nM
Compound 4: middle estimate off by 1.2-fold (0.08 log units), on the low side, and the stated range covers the measured number.
By their numbers in this assay, from the lowest: compound 2; then compounds 1, 4 and 3 (each within the scatter of the next).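

In this assay, 2-(trifluoromethyl)phenyl in place of 4-fluorophenyl on a sulfonyl sulfur gives a 1.4-fold lower number from compound 3 to compound 4 (0.16 log units; within the scatter), a step within the usual scatter, so the two compounds cannot be separated. Among the compounds shown here, this is the first comparison that changes one place only, and it shows that the number does not move beyond the scatter at this position, although the entering group has 10 heavy atoms against 7 for the group that leaves. No measurement on these compounds speaks to why the step is this small.

The compounds shown leave open whether an aryl group on the sulfonyl sulfur is needed at all, a question that a cyclohexyl group or a short alkyl chain at the same place would address in this assay. For the compounds shown here, the contribution of the sulfonyl sulfur itself also remains open, with no compound here differing from compound 3 or compound 4 at that atom alone.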